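This account rests on a few compounds, and the source may have more. Where it says the series, first, only, none or still open, it means among the compounds named here.

Measured in a physicochemical assay for lipophilicity, read by HPLC, at pH 7.4; a lower number here means a more polar compound, a higher number a more lipophilic compound:
- compound 1 `C[C@@H](Oc1cc2cnn(CCC(=O)O)c2cc1Cl)c1ccccn1`: 1.7
- compound 2 `Cc1ccc([C@@H](C)Oc2cc3onc(CCC(=O)O)c3cc2Cl)nc1`: 2.42
- compound 3 `C[C@@H](Oc1cc2oc(=O)n(CCC(=O)O)c2cc1Cl)c1cccnn1`: 0.83

Compound 2 has the highest number of the three, and its gaps to compound 1 and to compound 3 both lie beyond the scatter. Compound 4 `Cc1ccc([C@@H](C)Oc2cc3onc(CCC(=O)O)c3cc2Cl)nn1` keeps the core of compound 2 and exchanges one group: 6-methylpyridazin-3-yl in place of 5-methylpyridin-2-yl on a saturated chain carbon bound to an oxygen on an aromatic ring and a saturated chain carbon.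

For the measured compounds named here, no two measured compounds differ in one place only, so the data give no direct measure of this exchange. The nearest hint is indirect. Compound 3 also bears a pyridazinyl group on the corresponding carbon, though on a different core and without the methyl, and in this assay compound 3 gives 0.83. That comparison is loose, and it supports a direction more than a size.

A clear fall, beyond the scatter, is nevertheless expected, and the estimated change is a number 1.12 log units lower from compound 2 to compound 4 (beyond the scatter). The estimate for compound 4 is 1.3, with an expected range from 0.9 to 1.75.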

Compound 4, distribution coefficient: 2.97
Compound 4: middle estimate off by 1.67 log units, on the low side; measured number above the stated range.
By their numbers in this assay, from the lowest: compound 3; then compound 1; then compound 2; then compound 4.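

For the compounds shown here, the step is the first direct reading of a single exchange in this set: in this assay, 6-methylpyridazin-3-yl in place of 5-methylpyridin-2-yl on a saturated chain carbon bound to an oxygen on an aromatic ring and a saturated chain carbon gives a number 0.55 log units higher from compound 2 to compound 4 (beyond the scatter), with the rest of the structure unchanged. On this core, then, the six-membered aromatic ring with 2 hetero atoms ends with the higher number, not the ring with 1 hetero atom, and the step is modest in size although it lies beyond the scatter. Nothing in the data accounts for the direction of this step.

Going by these compounds alone, only this one pair of groups on this one core can be read, so it remains open whether the same exchange would move the number the same way on the core of compound 1 or the core of compound 3. Also open, from the compounds shown here alone, is where a phenyl or a pyrimidin-2-yl group at this place would fall, and what the methyl on the ring contributes on its own.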